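The source may hold more compounds than are shown below. What is called first, only, known or untested is meant among the compounds shown, and "the series" means these compounds.

Working notes on the series.

Compound 1 `COC1(c2cc(F)cc(Sc3ccc4c(c3)CC/C4=N\O)c2)CCOCC1` carries a hydrogen on an oxygen whose other neighbours are a double-bonded nitrogen. In a functional assay (blood) for inhibition, with Homo sapiens as the target (a lower number here means a stronger inhibitor, a higher number a weaker inhibitor), compound 1 gives 290 nM. Compound 3 `COC1(c2cc(F)cc(Sc3ccc4c(c3)CC/C4=N\OCC#N)c2)CCOCC1` differs from compound 1 in one place only: cyanomethyl in place of hydrogen on an oxygen. In this assay compound 3 gives 30 nM, and the step is a 9.7-fold lower number from compound 1 to compound 3 (0.99 log units; beyond the scatter).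

Compound 2 `CO[C@]1(c2cnc(S(=O)(=O)c3ccc(/C(C)=N/O)cc3)s2)CCO[C@@H](C)C1` stands on another core; the difference between the two cores is not broken down here. In this assay compound 2 gives 320 nM, which lies within the scatter of the value of compound 1, so no order between compound 1 and compound 2 is drawn. Against compound 3 the gap is beyond the scatter.

Compound 4 `CO[C@]1(c2cnc(S(=O)(=O)c3ccc(/C(C)=N/OCC#N)cc3)s2)CCO[C@@H](C)C1` is the counterpart of compound 3 on the core of compound 2: cyanomethyl in place of hydrogen on an oxygen. The place is the same as in the pair from compound 1 to compound 3, so this is the same change, seen only once so far in measured form. Among the compounds with values here, whether it carries over to a second core is untested, and the single precedent keeps the expectation loose. Still, because compound 3 showed a 9.7-fold lower number from compound 1 to compound 3 (0.99 log units; beyond the scatter), a step in the same direction is expected for compound 4, somewhat tempered for the change of core, namely a 6.4-fold lower number from compound 2 to compound 4 (0.81 log units; beyond the scatter). Compound 4 is therefore estimated at 50 nM, with a range from 18 nM to 150 nM.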

Compound 4, half-maximal inhibitory concentration: 140 nM
Compound 4: middle estimate off by 2.8-fold (0.45 log units), on the low side; low and high end bracket the measured number.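

In this assay, cyanomethyl in place of hydrogen on an oxygen again gives a lower number on the second core (a 2.3-fold lower number from compound 2 to compound 4 (0.36 log units; beyond the scatter)), so the direction of the change holds on both cores shown. The size of the step does not carry over, and the two steps differ: the same change on two cores in this assay, a 9.7-fold lower number (0.99 log units; beyond the scatter) from compound 1 to compound 3 and a 2.3-fold lower number (0.36 log units; beyond the scatter) from compound 2 to compound 4, 4.2-fold (0.63 log units) apart, beyond the scatter of two such steps

The change can therefore be read across these two cores for its direction but not for its size, and a step measured on one core is a poor guide to the size of the step on the other. These two pairs do not show which of the many differences between the cores goes with the smaller step, nor what the change would do on a third core.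

The compounds shown leave open whether the lower number goes with the nitrile itself or with any group placed on that oxygen, a question that a plain methyl, a longer chain ending in a nitrile or a chain ending in a carboxylic acid on the same oxygen would help to settle. Going by these compounds, it also remains open whether a core carrying only part of the difference between the two cores would give a step of intermediate size.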